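Removing the Methyl From the Pyridine Carbonyl Group

This account rests on a few compounds, and the source may have more. Where it says the series, first, only, none or still open, it means among the compounds named here.

Of the compounds shown here, three sharing one core have been tested in an ADME assay on HEK-293T cells (Homo sapiens) for cytotoxicity, read by MTT assay, with a stated time of 24 h; on this read-out higher numbers stand for lower toxicity in this test and lower numbers for higher toxicity in this test. Compound 1 `Cc1ccc(-c2nn(-c3ccccc3)cc2-c2nc3ccccc3n2C(=O)c2ccc(C)nc2)cc1` gives 145000 nM. Among the compounds with values here, compound 2 `O=C(c1ccccc1)n1c(-c2cn(-c3ccccc3)nc2-c2ccc(C(F)(F)F)cc2)nc2ccccc21` gives 168000 nM, and compound 3 `Cc1ccc(C(=O)n2c(-c3cn(-c4ccccc4)nc3-c3ccc(C(F)(F)F)cc3)nc3ccccc32)cn1` gives 153000 nM; both of these values lie within the usual scatter of the value for compound 1, so no compound can be said to stand apart from the others.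

Compound 4 `Cc1ccc(-c2nn(-c3ccccc3)cc2-c2nc3ccccc3n2C(=O)c2cccnc2)cc1` differs from compound 1 in one place: hydrogen in place of methyl on an aromatic carbon. Within the data shown here, no measured pair shows exactly this change. The two measured steps, a 1.1-fold higher number from compound 1 to compound 3 (0.02 log units; within the scatter) and a 1.1-fold lower number from compound 2 to compound 3 (0.04 log units; within the scatter), both stayed within the scatter, and the second of them concerns the same group on the carbonyl carbon. Neither step gives a reason to expect that losing a methyl here would move the value in this assay beyond the scatter in either direction.

Compound 4 is therefore estimated at 150000 nM, with a likely range from 90000 nM to 250000 nM. That estimate means a step of a 1.0-fold higher number from compound 1 to compound 4 (0.01 log units; within the scatter), expected to be no larger than the scatter.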

Compound 4, half-maximal cytotoxic concentration: 189000 nM
Compound 4: middle estimate off by 1.3-fold (0.10 log units), on the low side, and the stated range covers the measured number.
By their numbers in this assay, from the lowest: compounds 1, 3, 2 and 4 (each within the scatter of the next).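

Taking the methyl off the 6-methylpyridin-3-yl group to leave pyridin-3-yl gives a 1.3-fold higher number from compound 1 to compound 4 (0.12 log units; within the scatter) in this assay. Within the data shown here, this is the first direct reading of this position, which the earlier steps touched only by swapping the whole group on the carbonyl for phenyl: on the core of compound 1, the methyl next to the ring nitrogen can give way to hydrogen with the change staying within the scatter. Nothing available explains this result or tells what, if anything, the methyl contributes in this test.

Going by these compounds, it remains open whether a different group at this place, such as an amine, a carboxylic acid or a longer chain, would move the number beyond the scatter. On these data alone, it is also open whether removing this methyl from compound 3, which carries trifluoromethyl in place of the other methyl, would stay within the scatter too.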